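The compounds below may be only part of what the source reports. "The series", "measured", "known", "first", "only" and "open" are said of these compounds alone.

Compound 1 `Cc1nn(C)c(Oc2ccc(I)cc2)c1/C=N\CCCCCOc1cc2oc(=O)cc(C)c2cc1Cl`: > 25000 nM
Compound 2 `Cc1nn(C)c(Oc2ccccc2F)c1/C=N\CCCCCCOc1cc2oc(=O)cc(C)c2cc1Cl`: > 25000 nM
Compound 3 `Cc1nn(C)c(Oc2cccc(F)c2)c1/C=N\CCCCCCOc1cc2oc(=O)cc(C)c2cc1Cl`: 23600 nM

In a functional assay on SMMC-7721 cells (Homo sapiens) for antiproliferative activity, read by MTT assay, with a stated time of 72 h (on this read-out lower numbers stand for stronger inhibition and higher numbers for weaker inhibition), compound 1 reaches only a limit of the assay, > 25000 nM. Compound 2 likewise stops at a limit, > 25000 nM. Compound 3 is the only one of the three with a number, 23600 nM; the other two sit at the limit of > 25000 nM in this assay, at which 2 of the 3 values shown sit. Going by the values given here, the one measured step, an at least 1.0-fold lower number from compound 2 to compound 3 (0.02 log units; that floor lies within the scatter), stays within the scatter.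

Compound 4 `Cc1nn(C)c(Oc2ccc(F)cc2)c1/C=N\CCCCCCOc1cc2oc(=O)cc(C)c2cc1Cl` differs from compound 3 by 4-fluorophenyl in place of 3-fluorophenyl on an oxygen on an aromatic ring. Among the compounds with values here, no measured step covers this change directly; the only step that touches the fluorophenyl group stayed within the scatter, so compound 4 is expected to show no step beyond the scatter, a 1.1-fold higher number from compound 3 to compound 4 (0.03 log units; within the scatter). Compound 4 is therefore estimated at 25000 nM, within a range from 11000 nM to 55000 nM.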

Compound 4, half-maximal inhibitory concentration: 13500 nM
Compound 4: the middle estimate sits 1.9-fold (0.27 log units) above what was measured, within the range that was stated.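

With 4-fluorophenyl in place of 3-fluorophenyl on the oxygen, this assay gives a 1.7-fold lower number from compound 3 to compound 4 (0.24 log units; within the scatter), so a second change of fluorine placement also stays inside the scatter. Compared with the 2-fluorophenyl group, the result is an at least 1.8-fold lower number from compound 2 to compound 4 (0.26 log units; that floor lies within the scatter). That step is only a floor because compound 2 stands at a limit, not a number: the limit of > 25000 nM in this assay, at which 2 of the 4 values shown sit.

The compounds shown leave open whether an amine or a carboxylic acid in place of the fluorine, or a longer chain to the shared core, would bring a step beyond the scatter.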